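This account rests on a few compounds, and the source may have more. Where it says the series, first, only, none or still open, it means among the compounds named here.

Two compounds sharing one core have been run in an ADME assay on microsomes from liver (Homo sapiens), read by LC-MS, with a stated time of 90 min; a higher number here means that the liver removes a larger share of the compound in one pass, a lower number that the liver removes a smaller share. Compound 1, `CC[C@H](C)n1c(=O)[nH]c2ncc(Br)nc21`, returns only a limit of the assay, < 0.2. Compound 2, `CCC(CC)n1c(=O)[nH]c2ncc(Cl)nc21`, also returns only a limit of the assay, < 0.2. Compound 2 therefore stands where every value shown so far stands, at the limit of < 0.2 in this assay, at which 2 of the 2 values shown sit, and no value within this assay separates it from compound 1.

Compound 3, `CCC(CC)n1c(=O)[nH]c2ncc(C#N)nc21`, is not yet measured. It differs from compound 2 by cyano in place of chloro on an aromatic carbon. Among the compounds with values here, no pair of measured compounds differs in a single place, so no measured step shows how such a change moves this assay. Given that compound 2 sits at the limit, the expected step is a step that the limit leaves unreadable from compound 2 to compound 3, which is no movement beyond the usual scatter. Compound 3 is accordingly estimated at 0.15 in this assay, with a range from 0.05 to 0.3.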

Compound 3, hepatic extraction ratio: < 0.2
Compound 3 gave a limit, no number; the forecaster's own chance of this, stated with the estimate: 60%; the middle value lies beyond the limit too.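

No step from compound 2 to compound 3 can be read in this assay, because both compounds return only a limit of the assay: the limit of < 0.2 in this assay, at which 3 of the 3 values shown sit.

The compounds shown leave open whether cyano in place of chloro on an aromatic carbon moves this assay at all, and by how much.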